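A Fluorine Added to the Phenyl Ring of Compound 1

The compounds below may be only part of what the source reports. "The series", "measured", "known", "first", "only" and "open" are said of these compounds alone.

Compound 1 `O=C(Nc1nc2ccc(F)cc2s1)c1cn(-c2ccccc2)nc1-c1ccccc1` is an amide whose shared core carries a fluoro group. In a functional assay on A549 cells (Homo sapiens) for cytotoxicity, read by MTT assay, with a stated time of 72 h (a lower number here means a stronger inhibitor, a higher number a weaker inhibitor), compound 1 gives 10200 nM, the highest of the two plain numbers available. Compound 2 `O=C(Nc1nc2ccc(Cl)cc2s1)c1cn(-c2ccccc2)nc1-c1ccccc1` carries chloro in place of that fluoro, and in this assay compound 2 gives 7670 nM; the step of a 1.3-fold lower number from compound 1 to compound 2 (0.12 log units; within the scatter) stays within the scatter, so the two are not ranked against each other. Compound 3 `COc1ccc2nc(NC(=O)c3cn(-c4ccccc4)nc3-c3ccccc3)sc2c1` carries methoxy at the same place, and in this assay compound 3 is recorded only as a limit, > 50000 nM. The steps of an at least 4.9-fold higher number from compound 1 to compound 3 (0.69 log units; beyond the scatter) and an at least 6.5-fold higher number from compound 2 to compound 3 (0.81 log units; beyond the scatter) are both beyond the scatter, the only clear movements seen so far, and both concern the group on the shared core.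

Compound 4 `O=C(Nc1nc2ccc(F)cc2s1)c1cn(-c2ccccc2)nc1-c1ccc(F)cc1` differs from compound 1 in a different place: fluoro in place of hydrogen on an aromatic carbon, para to a large group, which read one bond further out is phenyl to 4-fluorophenyl. For the measured compounds named here, no measured step touches that ring, so the three steps in hand give no direct guide, and no change beyond the scatter is expected from a single fluoro entering there. Compound 4 is therefore expected to give about 9500 nM in this assay, with a range from 4000 nM to 25000 nM. The expected step is a 1.1-fold lower number from compound 1 to compound 4 (0.03 log units; within the scatter).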

Compound 4, half-maximal inhibitory concentration: 6650 nM
Compound 4: middle estimate off by 1.4-fold (0.15 log units), on the high side; the range from low to high includes it.
By their numbers in this assay, from the lowest: compounds 4, 2 and 1 (each within the scatter of the next). At a limit, above all of these: compound 3.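

The fluoro in compound 4 is the first change shown on this ring, phenyl to 4-fluorophenyl, and in this assay it gives a 1.5-fold lower number from compound 1 to compound 4 (0.19 log units; within the scatter), so compound 4 and compound 1 are not ranked against each other. This shows that, with fluoro on the shared core, one fluoro can replace hydrogen on this aromatic carbon, para to a large group, without a movement beyond the scatter, whereas the earlier steps spoke only of the group on the shared core, and the clear movements shown so far remain confined to that place. The information at hand offers no measured reason for the size of this step.

Fluoro is the only group shown at this ring position, so it remains open whether an amine, a carboxylic acid, a nitrile or a longer chain entering there would leave the number within the scatter or shift it clearly. It also remains open whether 4-fluorophenyl would give a similar step alongside chloro or methoxy on the shared core, since it is shown only with fluoro there.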